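Three compounds at the limit, and a fourth to come

The source may hold more compounds than are shown below. What is called first, only, known or untested is meant among the compounds shown, and "the series" means these compounds.

Values in a toxicity assay on HT-29 cells (Homo sapiens) for cytotoxicity (a higher number here means that more compound is tolerated, a lower number that less compound is tolerated), for three compounds:
Compound 1 `CN1C(=S)[C@@H](NC(=O)c2nc(Cc3ccccc3)n(C)n2)COc2ccccc21` gives > 100000 nM as a limit
Compound 2 `CCn1nc(C(=O)N[C@H]2COc3ccccc3N(C)C2=S)nc1Cc1ccccc1` gives > 100000 nM as a limit
Compound 3 `CN1C(=S)[C@@H](NC(=O)c2nc(Cc3ccccc3)n(C3CCC3)n2)COc2ccccc21` gives > 100000 nM as a limit

Compound 3 stands at > 100000 nM as a limit and not as a number. All that is known so far is the limit of > 100000 nM in this assay, at which 3 of the 3 values shown sit, and nothing more.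

The next compound is compound 4 `CN1C(=S)[C@@H](NC(=O)c2nc(Cc3ccccc3)n(CC3COC3)n2)COc2ccccc21` in which (oxetan-3-yl)methyl takes the place of cyclobutyl on an aromatic nitrogen (oxetan-3-yl)methyl in place of cyclobutyl on an aromatic nitrogen and the rest of the structure stays the same. The closest measured changes fall on that same nitrogen: a step that the two limits leave unreadable from compound 1 to compound 3 and a step that the two limits leave unreadable from compound 2 to compound 3 are the two that bear on it. Neither has a size that can be carried over, so the expectation is simply that nothing shifts beyond the scatter. The expected step is a number no higher from compound 3 to compound 4 (the limit leaves the size open) with no direction favoured. For compound 4 the estimate is 100000 nM with an expected range from 50000 nM to 200000 nM and another report as a limit is likely.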

Compound 4, half-maximal cytotoxic concentration: > 100000 nM
Compound 4 gave a limit, no number (the forecaster's own chance of this, stated with the estimate: 90%); the middle value sits exactly at the limit.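

No step between compound 1, compound 2, compound 3 and compound 4 can be read, because each result is a limit and not a number: the limit of > 100000 nM in this assay, at which 4 of the 4 values shown sit.

From the compounds shown here alone, whether these four compounds differ at all in this assay, and at what concentration any of them becomes toxic to the cells, stays open.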